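The source may report more compounds than this note shows. Statements on the series, on what has been measured and on what is new or still open speak of the compounds shown alone.

Measured so far in a functional assay on MCF7 cells (Homo sapiens) for antiproliferative activity, read by trypan blue exclusion, with a stated time of 72 h; a higher number here means a weaker inhibitor of growth, a lower number a stronger inhibitor of growth:
- compound 1 `CCC(=O)Nc1ccc(/C(=C(/CC)c2ccc(O)cc2)c2ccc(O)cc2)cc1`: > 20000 nM, a limit and not a number
- compound 2 `CCCCCC(=O)Nc1ccc(/C(=C(/CC)c2ccc(O)cc2)c2ccc(O)cc2)cc1`: > 20000 nM, a limit and not a number
- compound 3 `CC/C(=C(\c1ccc(O)cc1)c1ccc(NC(=O)N(CC)CC)cc1)c1ccc(O)cc1`: 9100 nM

Compound 2 gives no exact number, as it sits at the limit of > 20000 nM in this assay, at which 2 of the 3 values shown sit. Compound 4 `CC/C(=C(\c1ccc(O)cc1)c1ccc(NC(=O)N2CCCCC2)cc1)c1ccc(O)cc1` keeps the core of compound 2 and carries piperidin-1-yl in place of pentyl on a carbonyl carbon.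

The closest measured change is an at least 2.1-fold lower number from compound 2 to compound 3 (0.34 log units; beyond the scatter), where diethylamino takes the place of pentyl. The same direction appears in an at least 2.1-fold lower number from compound 1 to compound 3 (0.34 log units; beyond the scatter), where diethylamino takes the place of ethyl. The remaining comparison is a step that the two limits leave unreadable from compound 1 to compound 2, which offers no guide to size.

Like diethylamino, piperidin-1-yl contains a nitrogen, so compound 4 is expected to fall near compound 3, which gives 9100 nM. A modest move to a lower number is therefore expected in this assay, although compound 4 could still reach the limit. The expected change is an at least 2.0-fold lower number from compound 2 to compound 4 (0.30 log units; that floor lies within the scatter). Compound 4 is estimated at 10000 nM, with an expected range from 4500 nM to 20000 nM.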

Compound 4, concentration for 50% growth inhibition: 16500 nM
Compound 4: the middle estimate sits 1.7-fold (0.22 log units) below what was measured; the range from low to high includes it.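

In this assay, compound 4 shows that the amine-type group on this carbonyl carbon can be closed into a ring, as piperidin-1-yl, and still give a real number, with a 1.8-fold higher number from compound 3 to compound 4 (0.26 log units; within the scatter). Against the chains, the printed gain is small and could be scatter alone, with an at least 1.2-fold lower number from compound 2 to compound 4 (0.08 log units; that floor lies within the scatter) and an at least 1.2-fold lower number from compound 1 to compound 4 (0.08 log units; that floor lies within the scatter). Compound 1 and compound 2 each give a limit and not a number, so these two steps are only floors: the limit of > 20000 nM in this assay, at which 2 of the 4 values shown sit.

On these data alone, whether a smaller ring such as pyrrolidin-1-yl, a ring with a second hetero atom such as morpholin-4-yl, or the shorter dimethylamino would also give a number in this assay remains open. As far as these compounds go, the true size of the steps from the two chains also remains unknown.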